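This account rests on a few compounds, and the source may have more. Where it says the series, first, only, none or still open, it means among the compounds named here.

Compound 1 `COc1cccc(S(=O)(=O)Nc2ccc3oc(-c4ccccc4)nc3c2)c1` — in an ADME assay on HEK293 cells (Homo sapiens) for cytotoxicity, read by resazurin assay, with a stated time of 48 h (a lower number here means that less compound is tolerated, a higher number that more compound is tolerated), compound 1 gives 63000 nM.
Compound 2 `COc1ccc(S(=O)(=O)Nc2ccc3oc(-c4ccccc4)nc3c2)cc1` — in this assay compound 2 gives 91000 nM.
Compound 3 `O=S(=O)(Nc1ccc2oc(-c3ccccc3)nc2c1)c1ccc(Cl)s1` — in this assay compound 3 gives only > 100000 nM, which is a limit of the assay and not a number.

Compound 3 therefore stands at the top of what the series has shown: the limit of > 100000 nM in this assay, at which 1 of the 3 values shown sits. The next compound, compound 4 `COc1ccc(Cl)cc1S(=O)(=O)Nc1ccc2oc(-c3ccccc3)nc2c1`, changes the group on the sulfonyl sulfur: 5-chloro-2-methoxyphenyl in place of 5-chlorothiophen-2-yl on a sulfonyl sulfur.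

Among the compounds with values here, the steps that bear on this are an at least 1.5-fold higher number from compound 1 to compound 3 (0.20 log units; that floor lies within the scatter) and an at least 1.0-fold higher number from compound 2 to compound 3 (0.04 log units; that floor lies within the scatter), with a 1.4-fold higher number from compound 1 to compound 2 (0.16 log units; within the scatter) showing that moving the methoxy on the phenyl ring also stayed within the scatter. Nothing here points to a step beyond the scatter in either direction. Compound 4 is therefore expected at about 80000 nM, with a range from 40000 nM to 160000 nM. For compound 4 this estimate means an expected at least 1.2-fold lower number from compound 3 to compound 4 (0.09 log units; that floor lies within the scatter), with a fair chance that the assay again reports only a limit.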

Compound 4, half-maximal cytotoxic concentration: 74000 nM
Compound 4: the middle estimate sits 1.1-fold (0.03 log units) above what was measured, within the range that was stated.
By their numbers in this assay, from the lowest: compounds 1, 4 and 2 (each within the scatter of the next). At a limit, above all of these: compound 3.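

With 5-chloro-2-methoxyphenyl on the sulfonyl sulfur, this assay still shows no separation from the two methoxyphenyl compounds: a 1.2-fold lower number from compound 2 to compound 4 (0.09 log units; within the scatter) and a 1.2-fold higher number from compound 1 to compound 4 (0.07 log units; within the scatter). Against 5-chlorothiophen-2-yl the reading is an at least 1.3-fold lower number from compound 3 to compound 4 (0.13 log units; that floor lies within the scatter), and the true size of that step stays unknown. Compound 3 remains a limit of the assay and not a number: the limit of > 100000 nM in this assay, at which 1 of the 4 values shown sits.

Every group shown on the sulfonyl sulfur is an aromatic ring carrying methoxy or chlorine. Going by these compounds, whether an amine, a carboxylic acid or a longer alkyl chain there would give a step beyond the scatter stays open.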